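Pyrazoline Aryl Swap: Expecting Little Change in Cytotoxicity

The source may report more compounds than this note shows. Statements on the series, on what has been measured and on what is new or still open speak of the compounds shown alone.

Compound 1 `O=C(c1cccnc1)N1N=C(c2ccc(O)cc2)CC1c1ccccc1Cl` gives 47700 nM in an ADME assay on HepG2 cells (Homo sapiens) for cytotoxicity, read by MTT assay, with a stated time of 7 days; a lower number here means a stronger inhibitor, a higher number a weaker inhibitor. Compound 2 `COc1ccc(C2CC(c3ccc(O)cc3)=NN2C(=O)c2cccnc2)cc1C` gives 44800 nM in this assay. Compound 3 `COc1ccc(C2CC(c3ccc(O)cc3)=NN2C(=O)c2cccnc2)cc1OC` gives 53600 nM in this assay.

Compound 3 has the highest of the three numbers, but its separation from the others is small: the nearest is compound 1, and the step of a 1.1-fold higher number from compound 1 to compound 3 (0.05 log units; within the scatter) lies within the scatter, as does the step of a 1.2-fold higher number from compound 2 to compound 3 (0.08 log units; within the scatter). Compound 4 `CC(C)c1ccccc1C1CC(c2ccc(O)cc2)=NN1C(=O)c1cccnc1` is not yet measured and differs from compound 3 by 2-isopropylphenyl in place of 3,4-dimethoxyphenyl on a saturated ring carbon. Within the data shown here, the steps that bear on this change are those at the same saturated ring carbon: a 1.1-fold lower number from compound 1 to compound 2 (0.03 log units; within the scatter) and a 1.1-fold higher number from compound 1 to compound 3 (0.05 log units; within the scatter), both within the scatter, and the aryl substituent change a 1.2-fold higher number from compound 2 to compound 3 (0.08 log units; within the scatter), also within the scatter. No aryl variation at this position has moved the number beyond the scatter, so no step beyond the scatter is expected for compound 4. Compound 4 is therefore estimated at 50000 nM, with a range of 28000 nM to 90000 nM, meaning an expected step of a 1.1-fold lower number from compound 3 to compound 4 (0.03 log units; within the scatter).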

Compound 4, half-maximal inhibitory concentration: 49700 nM
Beside the measured number, compound 4's estimate is 1.0-fold (0.00 log units) above it; the measured number falls inside the stated range.
By their numbers in this assay, from the lowest: compounds 2, 1, 4 and 3 (each within the scatter of the next).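

In this assay, putting 2-isopropylphenyl, with 0 hydrogen-bond acceptors, in place of 3,4-dimethoxyphenyl, with 2, gives a 1.1-fold lower number from compound 3 to compound 4 (0.03 log units; within the scatter), so an all-carbon group on the saturated ring carbon keeps the number within the scatter of the oxygen-bearing one. The other two comparisons agree: the change from 4-methoxy-3-methylphenyl gives a 1.1-fold higher number from compound 2 to compound 4 (0.05 log units; within the scatter), and isopropyl in place of chloro on the aromatic carbon gives a 1.0-fold higher number from compound 1 to compound 4 (0.02 log units; within the scatter). No supporting information is available to explain why these changes leave the number within the scatter.

All four compounds carry a substituted phenyl group at this carbon and keep the (pyridin-3-yl)carbonyl and 4-hydroxyphenyl groups. As far as these compounds go, whether an amine or a carboxylic acid on that phenyl group, or a saturated ring in its place, would move the number beyond the scatter remains open.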